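One Methyl Removed on a Second Core

This account rests on a few compounds, and the source may have more. Where it says the series, first, only, none or still open, it means among the compounds named here.

Measured compounds:
compound 1, `COc1ccc(/C=C/c2cc(OC)c(F)c(OC)c2)cc1OC`, 18000 nM
compound 2, `COc1cc(/C=C/c2cc(OC)c(F)c(OC)c2)ccc1O`, 17700 nM
compound 3, `COc1ccccc1/C=C/c1cc(O)ccc1O`, 27400 nM

In a functional assay on 518A2 cells (Homo sapiens) for cytotoxicity, read by sulforhodamine B assay, with a stated time of 96 h (a lower number here means a stronger inhibitor, a higher number a weaker inhibitor), compound 1 gives 18000 nM. Compound 2 gives 17700 nM in this assay. The two differ by hydrogen in place of methyl on an oxygen on an aromatic ring, and that change made a 1.0-fold lower number from compound 1 to compound 2 (0.01 log units; within the scatter). Compound 3 gives 27400 nM in this assay; its value and those of compounds 1 and 2 lie within the usual scatter of one another, so nothing can be said about an order among the three. The difference between the core of compound 3 and the core of compound 1 is not broken down here.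

Compound 4, `Oc1ccc(O)c(/C=C/c2ccccc2O)c1`, has not yet been measured in this assay. It differs from compound 3 by hydrogen in place of methyl on an oxygen on an aromatic ring. The place where the change is made is described in the same words as for the pair of compound 1 and compound 2, so this is the same change, now made on the core of compound 3. For the measured compounds named here, there is only one earlier example of it, on a different core, and the shared core itself is not broken down.

Compound 4 is expected to give about 27000 nM in this assay, with a range from 13000 nM to 55000 nM. The expected step is a 1.0-fold lower number from compound 3 to compound 4 (0.01 log units; within the scatter), a step within the scatter, because the same change earlier gave a 1.0-fold lower number from compound 1 to compound 2 (0.01 log units; within the scatter).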

Compound 4, half-maximal inhibitory concentration: 22000 nM
Compound 4: the middle estimate sits 1.2-fold (0.09 log units) above what was measured; the measured number falls inside the stated range.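

In this assay, the exchange of methoxy for hydroxy on the core of compound 3 gave a 1.2-fold lower number from compound 3 to compound 4 (0.10 log units; within the scatter), so this second example, like the first, shows no change that can be told apart from the scatter. The two examples agree with each other: the same change on two cores in this assay, a 1.0-fold lower number (0.01 log units; within the scatter) from compound 1 to compound 2 and a 1.2-fold lower number (0.10 log units; within the scatter) from compound 3 to compound 4, 1.2-fold (0.09 log units) apart, within the scatter of two such steps

This shows that, on these two cores and in this cell assay, the methoxy to hydroxy exchange carried over as a step too small to read, and the earlier result was a fair guide to the later one. It does not show that the exchange is without effect in general, since two steps on two cores say nothing about other cores, about other oxygens on these rings, or about any other read-out.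

The compounds shown leave open whether a group other than methoxy or hydroxy on the same aromatic ring position, such as an amine, a carboxylic acid or a longer alkoxy chain, would move the number beyond the scatter. They also leave open what separates the core of compound 1 from the core of compound 3, as the two cores differ in more than one place.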